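A few compounds are considered here, and "the series" means these few. Any claim that something is new, unique, unknown or untested is made for them only; others in the source may bear on it.

Within the data shown here, compound 1 `COc1ccc(/C(=N/NC(=O)NNC(=O)NCCCC(C)Nc2cc(OC)cc3cccnc23)c2ccccc2)cc1` is the one compound of this set with a numeric result: in a functional assay on SW-620 cells (Homo sapiens) for inhibition, read by MTT assay, with a stated time of 4 days (a higher number here means a weaker inhibitor, a lower number a stronger inhibitor), compound 1 gives 7000 nM. Compound 2 `COc1cc(NC(C)CCCNC(=O)NN)c2ncccc2c1` stands differently, since the value reported for compound 2 in this assay is a limit of the assay, > 100000 nM, and not a number. It sits at the limit of > 100000 nM in this assay, at which 1 of the 2 values shown sits. Compound 3 `COc1cc(NC(C)CCCNC(=O)NNC(=O)NC(CO)(CO)CO)c2ncccc2c1` has not yet been measured in this assay. It is built from compound 2 by one change: (2-hydroxy-1,1-bis(hydroxymethyl)ethyl)carbamoyl in place of hydrogen on an amine nitrogen. Whether this addition brings compound 3 to a measurable potency cannot be read from compound 1, whose structure differs from compound 2 in far more than this one group. The account therefore expects compound 3 to stay close to the limit region. The step of a number no higher from compound 2 to compound 3 (the limit leaves the size open) is expected to be nothing beyond the scatter. Compound 3 is estimated at 100000 nM, within 30000 nM to 300000 nM.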

Compound 3, half-maximal inhibitory concentration: > 100000 nM
Compound 3: only a limit was reported (the forecaster's own chance of this, stated with the estimate: 70%); the middle value lies on the limit itself.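

Among these compounds, compound 3, like compound 2, is reported only as a limit of the assay and not as a number, so no step from compound 2 to compound 3 can be read. The compounds shown leave open whether the (2-hydroxy-1,1-bis(hydroxymethyl)ethyl)carbamoyl group changes potency at all.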